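A few compounds are considered here, and "the series" means these few. Any claim that something is new, unique, unknown or untested is made for them only; others in the source may bear on it.

Compound 3 `Cc1cc(CN(C2CCC2)C(CC(=O)O)c2ccc(Cl)cc2)ccc1OCCn1c(=O)ccn(C)c1=O` stands second highest of the three numbers recorded so far. In an assay on CHO cells for displacement of a labelled ligand from C-X-C chemokine receptor type 3 (Homo sapiens), with a stated time of 60 min (on this read-out lower numbers stand for stronger inhibition and higher numbers for weaker inhibition), compound 3 gives 95 nM. Compound 2 `Cc1cc(CN(CC2CC2)C(CC(=O)O)c2ccc(Cl)cc2)ccc1OCCn1c(=O)ccn(C)c1=O` gives 91 nM in this assay, and the step of a 1.0-fold higher number from compound 2 to compound 3 (0.02 log units; within the scatter) separates the two. Compound 1 `CCN(Cc1ccc(OCCn2c(=O)ccn(C)c2=O)c(C)c1)C(CC(=O)O)c1ccc(Cl)cc1` gives 428 nM; from it the steps of a 4.7-fold lower number from compound 1 to compound 2 (0.67 log units; beyond the scatter) and a 4.5-fold lower number from compound 1 to compound 3 (0.65 log units; beyond the scatter) are the only ones beyond the scatter, and both concern the group carried on the amine nitrogen.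

Compound 4 `COc1cc(CN(C2CCC2)C(CC(=O)O)c2ccc(Cl)cc2)ccc1OCCn1c(=O)ccn(C)c1=O` differs from compound 3 in one place: methoxy in place of methyl on an aromatic carbon. None of the three measured steps touches this part of the shared core; each of them changes the substituent on the amine nitrogen and leaves the aromatic methyl untouched. For the measured compounds named here, no measured step therefore bears directly on this change, and the expectation for compound 4 in this assay is a step of no size beyond the scatter, in either direction. The estimate for compound 4 is 100 nM, with an expected range from 35 nM to 300 nM. The expected step is a 1.1-fold higher number from compound 3 to compound 4 (0.02 log units; within the scatter).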

Compound 4, half-maximal inhibitory concentration: 152 nM
Estimate against measurement, compound 4: 1.5-fold (0.18 log units) below; the range from low to high includes it.
By their numbers in this assay, from the lowest: compounds 2, 3 and 4 (each within the scatter of the next); then compound 1.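

In this assay, the first change away from the amine nitrogen, methoxy in place of methyl on an aromatic carbon ortho to a large group and meta to a large group, gives a 1.6-fold higher number from compound 3 to compound 4 (0.20 log units; within the scatter). This aromatic carbon therefore accepts the extra oxygen, with its hydrogen-bond acceptor, without a step beyond the scatter, whereas a 4.5-fold lower number from compound 1 to compound 3 (0.65 log units; beyond the scatter) on the amine nitrogen lies beyond it. No measurement at hand accounts for this result.

The compounds shown leave open how ethoxy, chlorine or a hydroxyl group would read on this aromatic carbon, where only methyl and methoxy appear so far. Also open, on these data alone, is whether the same change gives a step of similar size when the amine nitrogen carries cyclopropylmethyl or ethyl instead of cyclobutyl.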